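Pyrazolyl for phenyl at the meta-substituted biaryl amide

This account rests on a few compounds, and the source may have more. Where it says the series, first, only, none or still open, it means among the compounds named here.

Going by the values given here, compound 3 `CNC(=O)N1CCCc2ccc(NC(=O)c3cccc(-c4ccccc4)c3)cc21` gives 1.39% in a functional assay on MV4-11 cells (Homo sapiens) for antiproliferative activity, with a stated time of 6 days, tested at 6.25 uM (on this read-out higher numbers stand for a stronger effect at the one concentration tested and lower numbers for a weaker effect), the lowest of the three numbers so far. Its nearest neighbour is compound 2 `CNC(=O)N1CCCc2ccc(NC(=O)c3ccc(-c4ccccc4)cc3)cc21`, which gives 74.3%, and compound 1 `CNC(=O)N1CCCc2ccc(NC(=O)c3ccc(-c4cc[nH]n4)cc3)cc21` gives 99.1%; both gaps lie beyond the scatter. Compound 4 `CNC(=O)N1CCCc2ccc(NC(=O)c3cccc(-c4cn[nH]c4)c3)cc21` is to be measured, and it differs from compound 3 as follows: 1H-pyrazol-4-yl in place of phenyl on an aromatic carbon.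

Among the compounds with values here, the one measured step that bears on this change runs the other way: a number 24.8 percentage points lower from compound 1 to compound 2 (beyond the scatter), a modest loss when the pyrazolyl is replaced by phenyl. Reversing that sense, a pyrazolyl in place of phenyl is expected to raise the number for compound 4, though the attachment point on the pyrazole differs and the place on the core is the one occupied by compound 3, where compound 2 and compound 3 already show a wide gap. The step is therefore estimated as a number 18.6 percentage points higher from compound 3 to compound 4 (beyond the scatter), upward but uncertain. Compound 4 is expected to give about 20%, within 0% to 55%.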

Compound 4, a percentage reported as inhibition, at one concentration (the size of the read-out at that concentration, not a potency): 77.7%
Compound 4: the middle estimate sits 57.7 percentage points below what was measured; the whole stated range lies below it.
By their numbers in this assay, from the lowest: compound 3; then compounds 2 and 4 (each within the scatter of the next); then compound 1.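

At the place meta to a large group, the change to 1H-pyrazol-4-yl from phenyl in this assay gives a number 76.3 percentage points higher from compound 3 to compound 4 (beyond the scatter), so the low number of compound 3 does not rule out this place for the series. The earlier step, a number 24.8 percentage points lower from compound 1 to compound 2 (beyond the scatter), also favoured the pyrazolyl-bearing compound, so both pairs shown now run in the same sense, although they differ in the place on the core and in the pyrazole attachment point. No available evidence accounts for the size of the new step.

Still open, on these data alone, is whether the gain needs the ring hydrogen on nitrogen, which a 1-methylpyrazol-4-yl group would test. As far as these compounds go, whether other groups at this place, such as an aminomethyl group or a carboxylic acid, keep the high number also remains open.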